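From 2,4-dichlorophenyl to 2-bromophenyl on a shared core

A few compounds are considered here, and "the series" means these few. Any claim that something is new, unique, unknown or untested is made for them only; others in the source may bear on it.

Compound 1 `NC1=NC2(CCOCC2)N(OCCCOc2cccc(Cl)c2Cl)C(N)=N1`: 330 nM
Compound 2 `NC1=NC2(CCOCC2)N(OCCCOc2ccc(Cl)cc2Cl)C(N)=N1`: "not determined" (no result reported)

Among the compounds with values here, in a functional assay on HepG2 cells (Homo sapiens) for antiproliferative activity, read by MTT assay, with a stated time of 72 h (a higher number here means a weaker inhibitor, a lower number a stronger inhibitor), compound 1 gives 330 nM, the only number available for this small set. Compound 2 has no number to stand on, and its entry reads "not determined" (no result reported). Within the data shown here, its place in this assay therefore remains open, and no step between measured compounds is available to size the next change.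

The next structure is compound 3 `NC1=NC2(CCOCC2)N(OCCCOc2ccccc2Br)C(N)=N1`, which has the same shared core. The change is 2-bromophenyl in place of 2,4-dichlorophenyl on an oxygen on a saturated carbon.

With only compound 1 at 330 nM as a reference, no step beyond the usual scatter is expected in this assay, in either direction. This expectation rests on very little data. For compound 3 the estimated value is 500 nM, with an expected range of 130 nM to 2000 nM.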

Compound 3, half-maximal inhibitory concentration: 860 nM
Compound 3: middle estimate off by 1.7-fold (0.24 log units), on the low side; the range from low to high includes it.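

In this assay the group on an oxygen on a saturated carbon now has its first measured step: 2-bromophenyl in place of 2,3-dichlorophenyl gives a 2.6-fold higher number from compound 1 to compound 3 (0.42 log units; beyond the scatter), a modest change but one beyond the usual scatter, with compound 1 the stronger of the pair. The step from compound 2 to compound 3 cannot be read, as compound 2 has no number to compare. No measured evidence is available to explain this difference.

This one swap changes both the halogen and the number of halogen atoms on the ring, so the compounds shown leave open which of the two matters. As far as these compounds go, a 2-chlorophenyl or an unsubstituted phenyl group at the same place would help to separate them, and the effect of a methoxy group there also remains unknown.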